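Cytotoxicity in BJ cells: from compound 3 to compound 4

The compounds below may be only part of what the source reports. "The series", "measured", "known", "first", "only" and "open" are said of these compounds alone.

Compound 1 `CC(C)N(Cc1cccc(OCCCCCC(=O)O)c1)C(=O)c1ccc(-c2ccc3c(c2)OCCO3)cc1` is one of three analogues tested in an ADME assay on BJ cells (Homo sapiens) for cytotoxicity, read by CellTiter-Glo and resazurin assay, with a stated time of 72 h; on this read-out lower numbers stand for an effect already at smaller amounts and higher numbers for an effect only at larger amounts of compound. For compound 1 the result is a limit of the assay, > 21900 nM. Compound 2 `CCOC(=O)CCCCCOc1cccc(CN(C(=O)c2ccc(-c3ccc4[nH]ccc4c3)cc2)C(C)C)c1` likewise gives only a limit, > 26000 nM. Compound 3 `CCOC(=O)CCCCCOc1cccc(CN(C(=O)c2ccc(-c3cccc(OCC)c3)cc2)C(C)C)c1` also stands at a limit, > 22300 nM. The step that the two limits leave unreadable from compound 2 to compound 3 is thus unreadable, as the limit of > 26000 nM in this assay, at which 1 of the 3 values shown sits, and the limit of > 22300 nM in this assay, at which 1 of the 3 values shown sits, show. Compound 4 `CCOC(=O)CCCCCOc1cccc(CN(C(=O)c2ccc(-c3ccc4c(c3)OCCO4)cc2)C(C)C)c1` differs from compound 3 by 2,3-dihydro-1,4-benzodioxin-6-yl in place of 3-ethoxyphenyl on an aromatic carbon. For the measured compounds named here, no measured step informs this change, since every value shown, including (the limit of > 21900 nM in this assay, at which 1 of the 3 values shown sits), is a limit. Compound 4 is therefore expected to show no step beyond the scatter, a step that the limit leaves unreadable from compound 3 to compound 4. In this assay compound 4 is estimated at 25000 nM, between 12000 nM and 60000 nM, most likely reported again as a limit.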

Compound 4, half-maximal effective concentration: > 24400 nM
Compound 4 was reported as a limit; the forecaster's own chance of this, stated with the estimate: 85%; the middle value does not contradict the limit.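

For the compounds shown here, compound 4 stands at a limit of the assay, as do compound 1, compound 2 and compound 3, so no step from any of these to compound 4 can be read. The compounds shown leave open at what concentration any of them would reach a half-maximal effect in this assay.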